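Hydroxymethyl for pyrazolyl on the spiro-imidazolidinone series

The source may hold more compounds than are shown below. What is called first, only, known or untested is meant among the compounds shown, and "the series" means these compounds.

Four compounds share one core, varied at the amide on the outer piperidine and at the aroyl group. In an assay on HEK293 cells for displacement of a labelled ligand from NPC1-like intracellular cholesterol transporter 1 (Homo sapiens) (a higher number here means a weaker inhibitor, a lower number a stronger inhibitor), compound 1 `CC(C)(C)OC(=O)NCCCCNC(=O)CN1CN(c2ccccc2)C2(CCN(C(=O)c3ccc(C(C)(C)C)cc3)CC2)C1=O` gives "not determined" (no result reported), and in this assay compound 2 `CCc1nn(CC)c(C2CCN(C(=O)CN3CN(c4ccccc4)C4(CCN(C(=O)c5ccc(C6CCCCC6)cc5)CC4)C3=O)CC2)c1C` gives "not determined" (no result reported), so compound 2 stands without a number of its own. Among the measured compounds shown here, compound 3 `CC(C)(C)OC(=O)NCCCNC(=O)CN1CN(c2ccccc2)C2(CCN(C(=O)c3ccc(C(C)(C)C)cc3)CC2)C1=O` is the only measured member: in this assay compound 3 gives 4500 nM. Compound 4 `O=C(CN1CN(c2ccccc2)C2(CCN(C(=O)c3ccc(C4CCCCC4)cc3)CC2)C1=O)N1CCC(CO)CC1` is unmeasured and is reached from compound 2 by the change (hydroxymethyl in place of 1,3-diethyl-4-methyl-1H-pyrazol-5-yl on a saturated ring carbon), hydroxymethyl in place of 1,3-diethyl-4-methyl-1H-pyrazol-5-yl on a saturated ring carbon. Because compound 2 has no value, the step to compound 4 cannot be placed as a direction or a size; the account expects the change to move the read-out in this assay by no more than the usual scatter in either direction, with compound 3 and its 4500 nM as the only anchor. On that basis compound 4 is estimated at 5000 nM in this assay, within a range from 1000 nM to 30000 nM.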

Compound 4, half-maximal inhibitory concentration: 1100 nM
Beside the measured number, compound 4's estimate is 4.5-fold (0.66 log units) above it; measured number inside the range.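

No new step can be read: compound 2 has no single number in this assay, and compound 3 and compound 4 differ in more than one place. The compounds shown leave open what hydroxymethyl in place of 1,3-diethyl-4-methyl-1H-pyrazol-5-yl does to the read-out. No evidence here bears on the result.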